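Swapping the Anilino Aryl Ring and Cell Growth Inhibition

The source may hold more compounds than are shown below. What is called first, only, known or untested is meant among the compounds shown, and "the series" means these compounds.

Compound 1 `N#Cc1c(Nc2ccccc2Cl)nc(SCc2cn(Cc3ccccc3Cl)nn2)nc1-c1ccccc1`: 8350 nM
Compound 2 `Cc1ccccc1Nc1nc(SCc2cn(Cc3ccc(Cl)cc3)nn2)nc(-c2ccccc2)c1C#N`: > 64000 nM

Among the measured compounds shown here, in a functional assay on B16-F10 cells (Mus musculus) for inhibition, read by MTT assay, with a stated time of 72 h (on this read-out higher numbers stand for weaker inhibition and lower numbers for stronger inhibition), compound 1 gives 8350 nM, the only numeric value in hand. Compound 2 reaches only > 64000 nM, which is a limit of this assay and not a number (the limit of > 64000 nM in this assay, at which 1 of the 2 values shown sits). Compound 3 `Cc1ccc(Nc2nc(SCc3cn(Cc4ccccc4Cl)nn3)nc(-c3ccccc3)c2C#N)cc1` differs from compound 1 by 4-methylphenyl in place of 2-chlorophenyl on a nitrogen on an aromatic ring. For the measured compounds named here, with no measured step of this kind to lean on, the step from compound 1 to compound 3 is expected to be a modest weakening, with the estimate a 2.4-fold higher number from compound 1 to compound 3 (0.38 log units; beyond the scatter) carrying wide uncertainty. Compound 3 is therefore expected to give about 20000 nM, within 6000 nM to 64000 nM.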

Compound 3, half-maximal inhibitory concentration: 3390 nM
Compound 3: middle estimate off by 5.9-fold (0.77 log units), on the high side; the measured number lies below the stated range.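

Changing the aryl ring on the nitrogen while everything else stays fixed has a real effect in this assay, with 4-methylphenyl in place of 2-chlorophenyl giving a 2.5-fold lower number from compound 1 to compound 3 (0.39 log units; beyond the scatter). Compound 3 also shows that a chlorine on this ring is not required for inhibition of these cells. Nothing measured here explains why the number falls. As far as these compounds go, it remains open whether the change comes from gaining the methyl, losing the chlorine, or moving the group on the ring. An unsubstituted phenyl, or a ring carrying an amine or a carboxylic acid, could help separate these possibilities.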